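Phenyl for Propyl on a Weakly Inhibiting Triazole Core

The source may report more compounds than this note shows. Statements on the series, on what has been measured and on what is new or still open speak of the compounds shown alone.

Measured compounds:
- Compound 1, `C=CCSc1nncc2cnc(CCC)n12`: in a functional assay for inhibition, with Homo sapiens as the target (on this read-out lower numbers stand for stronger inhibition and higher numbers for weaker inhibition), compound 1 gives > 48000 nM, which is a limit of the assay and not a number.
- Compound 2, `C=CCSc1nncc2cnc(-c3ccccc3)n12`: in this assay compound 2 gives > 48000 nM, again a limit of the assay.
- Compound 3, `CCCc1nnc(O)n2c(CCC)nc(C)c12`: in this assay compound 3 gives 16000 nM, the only real number among the three.

Compound 1 and compound 2 differ in one place: phenyl in place of propyl on an aromatic carbon. Because both values are limits, the step that the two limits leave unreadable from compound 1 to compound 2 cannot be read; this rests on (the limit of > 48000 nM in this assay, at which 2 of the 3 values shown sit). Compound 3 sits on a different core, and the difference between the two cores is not broken down here.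

Compound 4, `CCCc1nc(C)c2c(-c3ccccc3)nnc(O)n12`, has not yet been measured. It differs from compound 3 by phenyl in place of propyl on an aromatic carbon. This is the same kind of change as that from compound 1 to compound 2, but not the same: in compound 1 the propyl sits on a five-membered aromatic ring with 2 nitrogen, between two ring nitrogen atoms, whereas in compound 3 it sits on a six-membered aromatic ring with 3 nitrogen, next to the ring nitrogen and para to a hydroxy group.

Among the compounds with values here, since the only measured example of this kind of change gives no readable step, the expectation for compound 4 rests chiefly on compound 3 and its value 16000 nM, and the step of a 1.3-fold higher number from compound 3 to compound 4 (0.10 log units; within the scatter) is expected to be small. Compound 4 is therefore estimated at 20000 nM, within 5000 nM to 60000 nM in this assay.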

Compound 4, half-maximal inhibitory concentration: > 48000 nM
Compound 4: a limit, no number; the forecaster's own chance of this, stated with the estimate: 35%; at least 2.4-fold (0.38 log units) between middle value and limit.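

In this assay, phenyl in place of propyl on an aromatic carbon of the core of compound 3 gives an at least 3.0-fold higher number from compound 3 to compound 4 (0.47 log units; beyond the scatter), so on this core the change means weaker inhibition, by more than the usual scatter of repeated measurements. Compound 4 gives > 48000 nM, which is a limit of the assay and not a number, so the step has a known minimum but no known full size. Whether the change acts alike on both cores is not shown, because the step from compound 1 to compound 2 cannot be read, which leaves the step on the core of compound 3 with nothing to be compared against: the limit of > 48000 nM in this assay, at which 3 of the 4 values shown sit.

The compounds shown leave open whether the loss belongs to phenyl in particular, or whether other groups on the same aromatic carbon, such as a longer chain like butyl, an amine or a carboxylic acid, would keep or improve on the value of compound 3, 16000 nM. They also leave open how much of that value depends on the hydroxy group or on the other propyl of compound 3, since neither is varied here.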